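A few compounds are considered here, and "the series" means these few. Any claim that something is new, unique, unknown or untested is made for them only; others in the source may bear on it.

Measured so far:
compound 1, `CN1CCN(CCNCc2cn(-c3ccc([N+](=O)[O-])cc3)nc2-c2ccc(OC(F)(F)F)cc2)CC1`, 4400 nM
compound 2, `CN1CCN(CCNCc2cn(-c3ccc(C(F)(F)F)cc3)nc2-c2ccc(OC(F)(F)F)cc2)CC1`, 3000 nM
compound 3, `CCCN1CCC(CNCc2cn(-c3ccc([N+](=O)[O-])cc3)nc2-c2ccc(C(F)(F)F)cc2)CC1`, 2300 nM

All three were tested in an ADME assay on Huh-7 cells (Homo sapiens) for cytotoxicity; a higher number here means that more compound is tolerated, a lower number that less compound is tolerated. Compound 1 and compound 2 share a core and differ only by trifluoromethyl in place of nitro on an aromatic carbon; that change gave a 1.5-fold lower number from compound 1 to compound 2 (0.17 log units; within the scatter). Compound 3 carries a different core, and the difference between the two cores is not broken down here. Its value and those of compound 1 and compound 2 all lie within the usual scatter of one another.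

Compound 4, `CCCN1CCC(CNCc2cn(-c3ccc(C(F)(F)F)cc3)nc2-c2ccc(C(F)(F)F)cc2)CC1`, is not yet measured. It differs from compound 3 by trifluoromethyl in place of nitro on an aromatic carbon, the same change as from compound 1 to compound 2, at the same place. Because that earlier change gave a 1.5-fold lower number from compound 1 to compound 2 (0.17 log units; within the scatter), a similar small step is expected here, a 1.4-fold lower number from compound 3 to compound 4 (0.16 log units; within the scatter). For compound 4 in this assay the estimate is 1600 nM, expected to fall between 800 nM and 3500 nM.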

Compound 4, half-maximal cytotoxic concentration: 1200 nM
Compound 4: the middle estimate sits 1.3-fold (0.12 log units) above what was measured; the range from low to high includes it.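

In this assay, trifluoromethyl in place of nitro gave a 1.9-fold lower number from compound 3 to compound 4 (0.28 log units; within the scatter). Set beside the earlier case, the two steps agree: the same change on two cores in this assay, a 1.5-fold lower number (0.17 log units; within the scatter) from compound 1 to compound 2 and a 1.9-fold lower number (0.28 log units; within the scatter) from compound 3 to compound 4, 1.3-fold (0.12 log units) apart, within the scatter of two such steps. The change therefore carries across these two cores as a small step, but since each step lies within the scatter, this does not show that the swap has a real effect on how much compound is tolerated, and two pairs cannot speak for other cores in the series.

The compounds shown leave open whether another group in place of nitro, such as a nitrile, an amine or a carboxylic acid, would give a step beyond the scatter. They also leave open whether this small step would hold on a third core.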